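The compounds below may be only part of what the source reports. "The series", "measured", "known", "first", "only" and "open" are said of these compounds alone.

Measured in a functional assay on HL-60 cells (Homo sapiens) for cytotoxicity, read by MTT assay, with a stated time of 3 days; a higher number here means a weaker inhibitor, a lower number a stronger inhibitor:
- compound 1 `CCNc1nc(SCc2nc3ccccc3[nH]2)nc(-c2ccccc2)c1C#N`: 3.96 nM
- compound 2 `CN1CCN(c2nc(SCc3nc4ccccc4[nH]3)nc(-c3ccccc3)c2C#N)CC1`: 2.8 nM

Compound 2 holds the lower of these two numbers, but compound 1 lies within the scatter of it, so the pair cannot truly be ranked. Both are very low numbers for this assay, which makes compound 2 a strong starting point.

Compound 3 `N#Cc1c(-c2ccccc2)nc(SCc2nc3ccccc3[nH]2)nc1N1CCN(S(=O)(=O)c2ccccc2[N+](=O)[O-])CC1` keeps the rest of compound 2 and alters one place. On an amine nitrogen in a ring, (2-nitrophenyl)sulfonyl stands in place of methyl: (2-nitrophenyl)sulfonyl in place of methyl on an amine nitrogen in a ring.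

For the measured compounds named here, only one measured step bears on this: a 1.4-fold lower number from compound 1 to compound 2 (0.15 log units; within the scatter). That step swapped the whole group on an aromatic carbon and stayed within the scatter. Going by the values given here, it is weak guidance, since it did not alter the substituent on the amine nitrogen, and no measured compound carries a sulfonyl group. No shift beyond the scatter can therefore be forecast, in either direction, although the uncertainty is wide.

The expected step is a 1.8-fold higher number from compound 2 to compound 3 (0.25 log units; within the scatter). For compound 3 the estimated value is 5 nM, with an expected range from 1 nM to 30 nM.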

Compound 3, half-maximal inhibitory concentration: 2.77 nM
Estimate against measurement, compound 3: 1.8-fold (0.26 log units) above; the measured number falls inside the stated range.
By their numbers in this assay, from the lowest: compounds 3, 2 and 1 (each within the scatter of the next).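

In this assay, putting (2-nitrophenyl)sulfonyl in place of methyl on the amine nitrogen of the six-membered ring gives a 1.0-fold lower number from compound 2 to compound 3 (0.00 log units; within the scatter) and thus no readable change in the number. The earlier step altered only the group on an aromatic carbon, so it said nothing about this nitrogen; this step shows that, in this cell assay, the position can carry a group of 12 heavy atoms, with an added aromatic ring and 4 hydrogen-bond acceptors, in place of a single carbon without the number leaving the scatter. No measurement here accounts for this result, so the reason remains unknown.

The compounds shown leave open whether the nitro group contributes anything, since a plain phenylsulfonyl group would be needed to separate it from the rest of the new substituent. They also leave open how far this tolerance extends to other kinds of group on the same nitrogen, such as an acetyl group, a longer alkyl chain or a carboxylic acid.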